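A few compounds are considered here, and "the series" means these few. Any claim that something is new, unique, unknown or untested is made for them only; others in the source may bear on it.

Compound 1, `CCCCOC(=O)CNC(=O)[C@H](CSc1ccc([N+](=O)[O-])cc1[N+](=O)[O-])NC(=O)CC[C@H](NC(=O)CC(C)C)C(=O)OCCCC`, gives 59.6 uM in a toxicity assay on KB cells (Homo sapiens) for cytotoxicity, read by fluorescence, with a stated time of 3 days; on this read-out higher numbers stand for an effect only at larger amounts of compound and lower numbers for an effect already at smaller amounts.
Compound 2, `CCCCOC(=O)CNC(=O)[C@H](CSc1ccc([N+](=O)[O-])cc1[N+](=O)[O-])NC(=O)CC[C@H](N)C(=O)OCCCC`, gives 107 uM in this assay.
Compound 3, `CCCCOC(=O)CNC(=O)[C@H](CSc1ccc([N+](=O)[O-])cc1[N+](=O)[O-])NC(=O)CC[C@H](NC(=O)C(C)(C)C)C(=O)OCCCC`, gives 83.4 uM in this assay.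

Among these three, compound 1 stands at the low end of the numbers, but the gaps to the other two are within the scatter: from compound 1 the change to compound 3 brings a 1.4-fold higher number from compound 1 to compound 3 (0.15 log units; within the scatter), and the change to compound 2 brings a 1.8-fold higher number from compound 1 to compound 2 (0.25 log units; within the scatter). Both steps alter the group on the amine nitrogen of the shared core, once by exchanging the acyl chain and once by removing it, and neither moves the number beyond the scatter.

Compound 4, `CCCCOC(=O)CNC(=O)[C@H](CSc1ccc([N+](=O)[O-])cc1[N+](=O)[O-])NC(=O)CC[C@H](NC(=O)OC)C(=O)OCCCC`, carries the change (methoxy in place of isobutyl on a carbonyl carbon), so that the isobutylcarbonyl becomes a methoxycarbonyl at the same position. The two measured steps at this position, a 1.4-fold higher number from compound 1 to compound 3 (0.15 log units; within the scatter) and a 1.8-fold higher number from compound 1 to compound 2 (0.25 log units; within the scatter), both bear on it, and both were small. Compound 4 is therefore expected to show no step beyond the scatter in this assay, its number estimated at a 1.2-fold higher number from compound 1 to compound 4 (0.07 log units; within the scatter) relative to compound 1. For compound 4 the estimate is 70 uM, in the range 35 uM to 140 uM.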

Compound 4, concentration for half-maximal effect: > 300 uM
Compound 4: a limit, no number; the forecaster's own chance of this, stated with the estimate: 5%; at least 4.2-fold (0.63 log units) between middle value and limit.
By their numbers in this assay, from the lowest: compounds 1, 3 and 2 (each within the scatter of the next). At a limit, above all of these: compound 4.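

In this assay compound 4 gives > 300 uM, which is a limit of the assay and not a number. Among the compounds shown here, this is the first change at this position to reach beyond the scatter, and it does so against all three other compounds: an at least 5.0-fold higher number from compound 1 to compound 4 (0.70 log units; beyond the scatter), an at least 3.5-fold higher number from compound 3 to compound 4 (0.55 log units; beyond the scatter), and an at least 2.8-fold higher number from compound 2 to compound 4 (0.44 log units; beyond the scatter). Exchanging tert-butyl for isobutyl or removing the whole acyl group had left the numbers within the scatter of each other, so the loss of isobutyl alone does not account for the result, which rests on a single compound at the limit of the measurement: the limit of > 300 uM in this assay, at which 1 of the 4 values shown sits.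

As far as these compounds go, how far the true value of compound 4 lies past this limit stays open, and with it the full size of these steps. From the compounds shown here alone, it also stays open whether the result belongs to carbamate-type groups in general, as a longer ethoxycarbonyl or butoxycarbonyl on the same amine nitrogen would show, or to the methoxy alone, and whether a small acetyl would stand with compound 1 or with compound 4.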